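The compounds below may be only part of what the source reports. "The series", "measured", "known", "first", "only" and "open" are said of these compounds alone.

Among the compounds with values here, the three compounds measured so far share one core, and they differ in what sits on a six-membered ring at one end of it. Compound 1 is `Cc1ccc2nc(Nn3c(-c4ccc(Cl)cc4)nnc3-c3cccnc3)sc2c1`. In an ADME assay on MT4 cells (Homo sapiens) for cytotoxicity, read by MTT assay, with a stated time of 5 days (on this read-out lower numbers stand for higher toxicity in this test and higher numbers for lower toxicity in this test), compound 1 gives 75.5 ug/mL. Compound 2 is `Clc1ccc(-c2nnc(-c3cccnc3)n2Nc2nc3ccc(Cl)cc3s2)cc1`, and in this assay compound 2 gives 54.3 ug/mL. The change from compound 1 to compound 2 is chloro in place of methyl on an aromatic carbon; it gave a 1.4-fold lower number from compound 1 to compound 2 (0.14 log units; within the scatter). Compound 3 is `Cc1cccc2sc(Nn3c(-c4ccc(Cl)cc4)nnc3-c3cccnc3)nc12`, and in this assay compound 3 gives 36.5 ug/mL. Compound 3 and compound 1 are built from the same atoms joined differently; the difference between the two cores is not broken down here.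

The unmeasured compound 4 is `Clc1ccc(-c2nnc(-c3cccnc3)n2Nc2nc3c(Cl)cccc3s2)cc1`. Its relation to compound 3 is chloro in place of methyl on an aromatic carbon. Within the data shown here, this is the same kind of change as the one from compound 1 to compound 2, though not the same change: there the place was meta to a fused ring and para to a fused ring, here it is ortho to a fused ring and meta to a fused ring. Because the earlier step of a 1.4-fold lower number from compound 1 to compound 2 (0.14 log units; within the scatter) stayed within the scatter, the next step is also expected to be small, estimated as a 1.4-fold lower number from compound 3 to compound 4 (0.13 log units; within the scatter). Compound 4 is therefore expected to give about 27 ug/mL in this assay, with a likely range from 14 ug/mL to 55 ug/mL.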

Compound 4, half-maximal cytotoxic concentration: 27.2 ug/mL
Compound 4: middle estimate off by 1.0-fold (0.00 log units), on the low side, and the stated range covers the measured number.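

In this assay, putting chloro in place of methyl on an aromatic carbon gave a 1.3-fold lower number from compound 3 to compound 4 (0.13 log units; within the scatter), so on this second core the swap again left the number close to where it started. Set beside the earlier case, on a core built from the same atoms joined differently and with the swap at a different place on the ring, the two steps agree: the same change on two cores in this assay, a 1.4-fold lower number (0.14 log units; within the scatter) from compound 1 to compound 2 and a 1.3-fold lower number (0.13 log units; within the scatter) from compound 3 to compound 4, 1.0-fold (0.02 log units) apart, within the scatter of two such steps. This shows that in these two pairs the swap behaved alike and had only a small effect on the read-out, but it does not show that chloro truly lowers the number, since each step on its own stays within the usual scatter, and two pairs cannot show that the same would hold on any other core or in any other test.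

The compounds shown carry only methyl or chloro on this ring, which leaves open what a plain hydrogen, a methoxy group, an amine or a carboxylic acid would do there. From the compounds shown here alone, the rest of the molecule is the same in all four compounds, so how the number responds to changes elsewhere also remains open.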